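The source may report more compounds than this note shows. Statements on the series, on what has been measured and on what is new or still open speak of the compounds shown alone.

Going by the values given here, compound 1 `O=c1c(CNc2ccc(S(=O)(=O)Nc3nccs3)cc2)coc2ccccc12` is the one compound of this set for which a functional assay on A549 cells (Homo sapiens) for cytotoxicity, read by sulforhodamine B assay, with a stated time of 72 h (on this read-out higher numbers stand for weaker inhibition and lower numbers for stronger inhibition), returns a number: compound 1 gives 25600 nM in this assay. Its two companions sit at the limit of > 100000 nM in this assay, at which 2 of the 3 values shown sit. Compound 2 `Cc1cc(NS(=O)(=O)c2ccc(NC3=NC(=O)/C(=C\c4coc5ccccc5c4=O)S3)cc2)no1` reaches only a limit of this assay, reported as > 100000 nM. Compound 3 `CCOC1Oc2ccccc2C(=O)/C1=C/Nc1ccc(S(=O)(=O)Nc2ncccn2)cc1` likewise reaches only a limit of this assay, reported as > 100000 nM. Among the compounds with values here, compound 1 therefore stands alone in the readable range, while no step between two measured compounds can be stated, since the other two values are limits and not numbers.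

Compound 4 `O=c1c(CNc2ccc(S(=O)(=O)Nc3ncccn3)cc2)coc2ccccc12` keeps the core of compound 1 and changes one group on the sulfonamide nitrogen: pyrimidin-2-yl in place of 1,3-thiazol-2-yl on a sulfonamide nitrogen. Both groups that leave and enter are aromatic rings with two hetero atoms, neither carrying a hydrogen-bond donor, and both hold the same count of hydrogen-bond acceptors. With no measured step of this kind among the compounds shown, the expected step of a 1.3-fold higher number from compound 1 to compound 4 (0.10 log units; within the scatter) is judged small, within or barely beyond the usual scatter, with a mild lean toward weaker inhibition. Compound 4 is therefore estimated at 32000 nM in this assay, within a range from 10000 nM to 100000 nM.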

Compound 4, half-maximal inhibitory concentration: 85300 nM
The estimate for compound 4 lay 2.7-fold (0.43 log units) below the measured number, within the range that was stated.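

In this assay, the sulfonamide nitrogen of the core of compound 1 proves to be a place where the choice of ring changes the result: pyrimidin-2-yl in place of 1,3-thiazol-2-yl gives a 3.3-fold higher number from compound 1 to compound 4 (0.52 log units; beyond the scatter), a modest step beyond the scatter. Going by these compounds alone, this is the first step in the set that can be read, and it shows that these two aromatic rings, although they hold the same counts of hydrogen-bond donors and acceptors, are not interchangeable on this nitrogen, since the pyrimidin-2-yl compound inhibits more weakly. The change still leaves compound 4 with a readable number, whereas the values of compound 2 and compound 3 are limits and not numbers: the limit of > 100000 nM in this assay, at which 2 of the 4 values shown sit.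

Steps to compound 2 and compound 3 cannot be read, and this single step therefore supports no wider pattern. The compounds shown leave open how a phenyl or pyridin-2-yl ring, or a simple methyl group, would fare on the sulfonamide nitrogen, and whether the step from 1,3-thiazol-2-yl to pyrimidin-2-yl keeps its size on another core.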